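This account rests on a few compounds, and the source may have more. Where it says the series, first, only, none or still open, it means among the compounds named here.

Compound 1 `O=C1NC(=O)C2(CC2c2ccc3cccc(OCc4ccccc4)c3n2)N1` is the parent of this small set, and in a functional assay on the whole organism (strain Kunming) with Mus musculus as the target, with a stated time of 0.5 h (on this read-out higher numbers stand for an effect only at larger amounts of compound and lower numbers for an effect already at smaller amounts), compound 1 gives 300 mg/kg. Compound 2 `O=C1NC2(CC2c2ccc3cccc(OCc4ccccc4)c3n2)C(=O)N1c1ccc([N+](=O)[O-])cc1` carries a 4-nitrophenyl in place of hydrogen on an amide-type nitrogen in a ring, and in this assay compound 2 gives 300 mg/kg; the step of no change at the digits printed from compound 1 to compound 2 (within the scatter) shows no change within the scatter, so compound 2 stands level with compound 1. Compound 3 `COc1ccc(N2C(=O)NC3(CC3c3ccc4cccc(OCc5ccccc5)c4n3)C2=O)cc1` differs from compound 2 by methoxy in place of nitro on an aromatic carbon. Within the data shown here, only one measured step bears on this change, and it was flat, so a step of no size beyond the scatter is expected, no change at the digits printed from compound 2 to compound 3 (within the scatter). Compound 3 is estimated at 300 mg/kg, with a range from 150 mg/kg to 600 mg/kg.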

Compound 3, minimum effective dose: 300 mg/kg
Compound 3: the middle estimate sits on the measured number at the digits printed, within the range that was stated.
By their numbers in this assay, from the lowest: compounds 1, 2 and 3 (each within the scatter of the next).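

Methoxy in place of nitro on an aromatic carbon, para to a large group, leaves the read-out in this assay flat, with no change at the digits printed from compound 2 to compound 3 (within the scatter). The 4-methoxyphenyl in place of hydrogen on the amide-type nitrogen in a ring gives no change at the digits printed from compound 1 to compound 3 (within the scatter), so two different para-substituted phenyl groups on that nitrogen now read level with the parent. Nothing measured here speaks to what lies behind this flat result.

As far as these compounds go, whether an amine or a carboxylic acid at that para place, or a longer chain on that nitrogen, would shift the minimum effective dose stays open.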